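Removing the terminal nitrile from the chain of compound 2

This account rests on a few compounds, and the source may have more. Where it says the series, first, only, none or still open, it means among the compounds named here.

Three compounds share one core and differ in the groups attached to it: compound 1 `CCCCCCc1cc(C(C)=O)c(O)cc1OCCCCC#N`, compound 2 `C=CCc1cc(C(C)=O)c(O)cc1OCCCCCCCC#N` and compound 3 `CCc1cc(C(C)=O)c(O)cc1OCCCC(C)(C)c1nnn[nH]1`. In an assay on isolated protein for inhibition of leukotriene B4 receptor 1 (Homo sapiens), tested at 10 uM (on this read-out higher numbers stand for more inhibition at the one concentration tested (going by the name of the read-out) and lower numbers for less inhibition), compound 1 gives 51%, compound 2 gives 88% and compound 3 gives 100%. Compound 2 therefore stands second highest of the three numbers: compound 3 lies above it by a margin beyond the scatter, and compound 1 lies below it by a wider margin, also beyond the scatter. Compound 4 `C=CCc1cc(C(C)=O)c(O)cc1OCCCCCCC` keeps everything else of compound 2 and differs by hydrogen in place of cyano on a saturated chain carbon, seven bonds along the chain from an oxygen on an aromatic ring. Among the measured compounds shown here, no measured pair shows this change, so its size is open, but a decrease in this assay beyond the scatter is expected. For compound 4 the estimated value is 60%, within 35% to 85%, which means an expected step of a number 28 percentage points lower from compound 2 to compound 4 (beyond the scatter).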

Compound 4, a percentage reported as inhibition, at one concentration (the size of the read-out at that concentration, not a potency): 31%
Estimate against measurement, compound 4: 29 percentage points above; the whole stated range lies above it.
By their numbers in this assay, from the lowest: compound 4; then compound 1; then compound 2; then compound 3.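

In this assay, hydrogen in place of cyano on a saturated chain carbon, seven bonds along the chain from an oxygen on an aromatic ring, gives a number 57 percentage points lower from compound 2 to compound 4 (beyond the scatter). Among the compounds shown here, this is the first single-place comparison, and it shows that the read-out is sensitive to this change at this position. Nothing at hand accounts for the size of the step.

From the compounds shown here alone, whether a carboxylic acid or a primary amide in place of the cyano would keep the value of compound 2 remains open. So does the effect of a longer chain carrying the nitrile.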